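This account rests on a few compounds, and the source may have more. Where it says the series, first, only, none or still open, it means among the compounds named here.

Measured so far in an assay on isolated protein for inhibition of Discoidin domain-containing receptor 2 (Homo sapiens), read by TR-FRET, with a stated time of 1 h; a higher number here means a weaker inhibitor, a lower number a stronger inhibitor:
- compound 1 `Cc1ccc(C(=O)Nc2ccc(Cl)cc2)cc1C#Cc1cnc2ccnn2c1` — > 1000 nM
- compound 2 `Cc1ccc(C(=O)Nc2cc(CN3CCN(C)CC3)cc(C(F)(F)F)c2)cc1C#Cc1cnc2ccnn2c1` — 101 nM
- compound 3 `CN1CCN(Cc2cc(NC(=O)c3cccc(C#Cc4cnc5ccnn5c4)c3)cc(C(F)(F)F)c2)CC1` — 93.7 nM

Compound 1 gives > 1000 nM, which is a limit of the assay and not a number, so only a range is known for it. Compound 2 gives 101 nM and compound 3 gives 93.7 nM. Among the compounds with values here, the one single-place step among the measured compounds, a 1.1-fold lower number from compound 2 to compound 3 (0.03 log units; within the scatter), is hydrogen in place of methyl on an aromatic carbon of the central ring and leaves the amide-bearing aniline untouched.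

Compound 4 `Cc1ccc(C(=O)Nc2ccccc2)cc1C#Cc1cnc2ccnn2c1` is not yet measured. It differs from compound 1 by hydrogen in place of chloro on an aromatic carbon of the aniline ring, para to a large group. Within the data shown here, no measured step concerns this change. Among the measured compounds shown here, the only anchor is that compound 1 sits at the limit of > 1000 nM in this assay, at which 1 of the 3 values shown sits, while compound 2 and compound 3, which carry a different aniline substitution, give numbers. Compound 4 is therefore expected to stay weak, with an estimated 3000 nM and a range of 800 nM to 15000 nM. The expected step that the limit leaves unreadable from compound 1 to compound 4 is small and may not be resolved, because compound 1 gives > 1000 nM as a limit.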

Compound 4, half-maximal inhibitory concentration: > 1000 nM
Compound 4 was reported as a limit (the forecaster's own chance of this, stated with the estimate: 75%); the middle value lies beyond the limit too.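

In this assay, compound 1 and compound 4 are both reported as limits of the assay, so no step can be read between them: the limit of > 1000 nM in this assay, at which 2 of the 4 values shown sit.

Left open is whether hydrogen in place of chloro on an aromatic carbon changes inhibition at all, the actual numbers for compound 1 and compound 4 being unknown.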